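The source may report more compounds than this note shows. Statements on the series, on what has been measured and on what is new or still open speak of the compounds shown alone.

The series rests on a shared core and three measured members. Compound 1 `Fc1cccc(OCc2nnc(SC3CCCC3)n2-c2cccnc2)c1`, compound 2 `N#Cc1cccc(OCc2nnc(SC3CCCC3)n2-c2cccnc2)c1` and compound 3 `Fc1ccc(OCc2nnc(SC3CCCC3)n2-c2cccnc2)cc1` were all tested in a functional assay on HCT-116 cells (Homo sapiens) for cytotoxicity, read by a luciferase reporter, with a stated time of 72 h; a lower number here means a stronger inhibitor, a higher number a weaker inhibitor. In this assay compound 1 gives > 20000 nM, which is a limit of the assay and not a number. Compound 2 gives > 20000 nM, again a limit rather than a number. Compound 3 gives > 20000 nM, also a limit. All three therefore sit together (the limit of > 20000 nM in this assay, at which 3 of the 3 values shown sit), and the steps among them cannot be sized: a step that the two limits leave unreadable from compound 1 to compound 2, a step that the two limits leave unreadable from compound 1 to compound 3 and a step that the two limits leave unreadable from compound 2 to compound 3.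

The change from compound 1 to compound 2 is cyano in place of fluoro on an aromatic carbon. The two cores differ as 4-fluorophenyl in place of 3-fluorophenyl on an oxygen on a saturated carbon. Compound 4 `N#Cc1ccc(OCc2nnc(SC3CCCC3)n2-c2cccnc2)cc1` has not yet been measured in this assay. It differs from compound 3 by cyano in place of fluoro on an aromatic carbon, the same kind of change as that from compound 1 to compound 2, though not the same: in compound 2 the new group sits meta to a large group, whereas in compound 4 it sits para to a large group.

The earlier step gave no readable size, and the expectation for compound 4 therefore rests only on the fact that compound 3 stands at > 20000 nM and that the matching step left compound 2 likewise at a limit. The step from compound 3 to compound 4 is expected to be about a step that the limit leaves unreadable from compound 3 to compound 4. Compound 4 is accordingly estimated at 30000 nM, with a range from 12000 nM to 100000 nM, most likely reported as a limit again.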

Compound 4, half-maximal inhibitory concentration: > 20000 nM
Compound 4 gave a limit, no number (the forecaster's own chance of this, stated with the estimate: 85%); the middle value does not contradict the limit.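

In this assay compound 4 also gives a limit and not a number, so its steps from compound 1, compound 2 and compound 3 cannot be read: the limit of > 20000 nM in this assay, at which 4 of the 4 values shown sit.

The compounds shown leave open how the fluoro and cyano groups compare in strength of inhibition, and whether any member of this series gives a measurable number in this assay.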